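Chlorine on the Shared Core: Predicting the Next Antagonist

The source may hold more compounds than are shown below. What is called first, only, known or untested is meant among the compounds shown, and "the series" means these compounds.

Compound 1, `CNc1ncnc2c1ncn2CCC(COP(=O)(O)O)COP(=O)(O)O`: 480 nM
Compound 2, `CNc1nc(Cl)nc2c1ncn2CCC(COP(=O)(O)O)COP(=O)(O)O`: 1600 nM
Compound 3, `CNc1ncnc2c1ncn2CC(COP(=O)(O)O)COP(=O)(O)O`: 1090 nM

All three compounds were tested in a functional assay for antagonist activity at P2Y purinoceptor 1 (Homo sapiens); on this read-out lower numbers stand for stronger inhibition and higher numbers for weaker inhibition. Compound 3 gives the second highest of the three numbers. Its nearest neighbour is compound 2, whose value sits within the usual scatter of compound 3, so no order can be drawn between those two. Compound 1 stands furthest away, with a lower number that lies beyond the scatter.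

Compound 4, `CNc1nc(Cl)nc2c1ncn2CC(COP(=O)(O)O)COP(=O)(O)O`, has not yet been measured. It differs from compound 3 in one place: chloro in place of hydrogen on an aromatic carbon. The same exchange has already been seen once among the measured compounds, in the pair compound 1 and compound 2, where it gave a 3.3-fold higher number from compound 1 to compound 2 (0.52 log units; beyond the scatter). Among the measured compounds shown here, that single step is the only direct guide, and it points towards weaker inhibition.

The expectation is therefore that compound 4 will follow the same direction, with a step of about a 3.2-fold higher number from compound 3 to compound 4 (0.51 log units; beyond the scatter) from compound 3. On that basis compound 4 is estimated to give 3500 nM in this assay, with a plausible range from 1500 nM to 8000 nM. A single precedent is a thin basis, so the range is kept wide.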

Compound 4, half-maximal inhibitory concentration: 840 nM
Estimate against measurement, compound 4: 4.2-fold (0.62 log units) above, and the stated range ends above it.
By their numbers in this assay, from the lowest: compounds 1, 4, 3 and 2 (each within the scatter of the next, the first and the last beyond it).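

On the core of compound 3, chloro in place of hydrogen on the aromatic carbon between two ring nitrogen atoms carries no penalty that can be told from scatter in this assay, with a 1.3-fold lower number from compound 3 to compound 4 (0.11 log units; within the scatter). The weaker inhibition seen with this exchange on the core of compound 1 is therefore not a fixed cost of placing chloro at this position, and the two pairs disagree by more than repeated measurements would explain: the same change on two cores in this assay, a 3.3-fold higher number (0.52 log units; beyond the scatter) from compound 1 to compound 2 and a 1.3-fold lower number (0.11 log units; within the scatter) from compound 3 to compound 4, 4.3-fold (0.64 log units) apart, beyond the scatter of two such steps. The two cores differ only in the chain that carries the two phosphate groups, so the effect of this exchange depends on which of the two cores bears it, although two pairs are too few to make a general rule.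

Going by these compounds, it remains open how the exchange would behave with a longer chain between the core and the two phosphate groups, and so whether its effect changes steadily with chain length or only differs between these two cores. On these data alone, it is also open whether an amine or a bromo group on the same aromatic carbon would show the same dependence on the core as chloro does.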